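A few compounds are considered here, and "the series" means these few. Any claim that something is new, unique, unknown or untested is made for them only; others in the source may bear on it.

Among the measured compounds shown here, in a functional assay on HepG2 cells (Homo sapiens) for inhibition, read by MTT assay, with a stated time of 72 h (a lower number here means a stronger inhibitor, a higher number a weaker inhibitor), compound 2 `C=C(c1ccc(Cl)c(Cl)c1Cl)C1COC(C)(C)OO1` gives 27300 nM as the only actual number so far. Compound 1 `C=C(c1ccc(Cl)c(Cl)c1)C1COC(C)(C)OO1` gives > 100000 nM as a limit of the assay, not a number. Compound 3 `C=C(c1ccc(Cl)cc1Cl)C1COC(C)(C)OO1` has not yet been measured. It differs from compound 2 by hydrogen in place of chloro on an aromatic carbon with hydrogen in place of chloro on an aromatic carbon, ortho to two chloro groups. For the measured compounds named here, one measured step bears on this only in part, namely an at least 3.6-fold lower number from compound 1 to compound 2 (0.56 log units; beyond the scatter) with a chloro in place of hydrogen on a different aromatic carbon. The size of that step rests on the limit of > 100000 nM in this assay, at which 1 of the 2 values shown sits, and is therefore only a bound. Removing a chloro is the opposite kind of change, so a higher number of similar or smaller size is expected in this assay for compound 3. The estimate means an expected 2.2-fold higher number from compound 2 to compound 3 (0.34 log units; beyond the scatter) in this assay. Compound 3 is expected at 60000 nM (range 25000 nM to 100000 nM) by this estimate.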

Compound 3, half-maximal inhibitory concentration: 90500 nM
Compound 3: the middle estimate sits 1.5-fold (0.18 log units) below what was measured; low and high end bracket the measured number.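

In this assay, the chloro ortho to two chloro groups clearly counts: replacing it with hydrogen gives a 3.3-fold higher number from compound 2 to compound 3 (0.52 log units; beyond the scatter). Among the compounds shown here, this is the first step here with an actual number at both ends, so its size is known and not merely bounded, and it shows that compound 2 loses strength when this chloro goes, just as it differs from compound 1 at the other place. Compound 1 stands at a limit of the assay, so the earlier step remains only a bound: the limit of > 100000 nM in this assay, at which 1 of the 3 values shown sits.

The compounds shown leave open whether this effect belongs to chloro itself or would also appear with a bromo, methyl or methoxy group at this place. They also leave open whether the same change would matter on a different core.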